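The compounds below may be only part of what the source reports. "The series", "measured", "known", "first", "only" and "open" are said of these compounds alone.

Of the compounds shown here, two built on the same core have been measured in an assay on HEK293 cells for displacement of a labelled ligand from NPC1-like intracellular cholesterol transporter 1 (Homo sapiens); on this read-out lower numbers stand for stronger inhibition and higher numbers for weaker inhibition. Compound 1 `CC(C)(C)OC(=O)NCCCNC(=O)CN1CN(c2ccccc2)C2(CCN(C(=O)c3ccc(C4CCCCC4)cc3)CC2)C1=O` gives 6000 nM in this assay. Compound 2 `CS(=O)(=O)NCCNC(=O)CN1CN(c2ccccc2)C2(CCN(C(=O)c3ccc(C4CCCCC4)cc3)CC2)C1=O` gives 2100 nM in this assay. Among the measured compounds shown here, the single step between them, a 2.9-fold lower number from compound 1 to compound 2 (0.46 log units; beyond the scatter), is the only measured step available, and on these two numbers compound 2 stands at the lower end, with compound 1 as its only neighbour. Compound 3 `CS(=O)(=O)NCCCNC(=O)CN1CN(c2ccccc2)C2(CCN(C(=O)c3ccc(C4CCCCC4)cc3)CC2)C1=O` has not yet been measured. It differs from compound 2 in one place: (methanesulfonamido)methyl in place of methanesulfonamido on a saturated chain carbon, two bonds along the chain from an amide-type nitrogen; read one bond further out, a 2-(methanesulfonamido)ethyl chain becomes a 3-(methanesulfonamido)propyl chain. For the measured compounds named here, the step from compound 1 to compound 2 exchanged one group for another while the chain length also changed, so it does not separate the part played by the chain from that of the group, and no measured step isolates the change now made. For compound 3 the expected step is a 1.2-fold higher number from compound 2 to compound 3 (0.08 log units; within the scatter), which lies within the scatter. Compound 3 is therefore expected to give about 2500 nM in this assay, within a range from 900 nM to 7000 nM.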

Compound 3, half-maximal inhibitory concentration: 3800 nM
The estimate for compound 3 lay 1.5-fold (0.18 log units) below the measured number; the measured number falls inside the stated range.
By their numbers in this assay, from the lowest: compounds 2, 3 and 1 (each within the scatter of the next, the first and the last beyond it).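

Compound 3 supplies what the first pair lacked, a step in this assay that changes only the chain, taking a 2-(methanesulfonamido)ethyl chain to a 3-(methanesulfonamido)propyl chain (a 1.8-fold higher number from compound 2 to compound 3 (0.26 log units; within the scatter)), so at this position the two chain lengths cannot be told apart on these numbers. It also isolates the end group on the propyl chain, with methylsulfonyl in place of tert-butoxycarbonyl on the amine nitrogen (a 1.6-fold lower number from compound 1 to compound 3 (0.20 log units; within the scatter)), and this exchange likewise stays inside the usual variation between repeated measurements. Neither change alone therefore clears the scatter, whereas the two made together, in the earlier step (a 2.9-fold lower number from compound 1 to compound 2 (0.46 log units; beyond the scatter)), do clear it, which gives the first pair's difference a more cautious reading: it belongs to the combined change and cannot be assigned to the chain or to the group alone.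

No other measurement here offers an explanation for the size of these steps. Still open, on these data alone, is whether a longer chain than propyl, or an amine or a carboxylic acid at the chain end, would move the number beyond the scatter in this assay.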